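This account rests on a few compounds, and the source may have more. Where it says the series, first, only, none or still open, it means among the compounds named here.

Compound 2 `Nc1ccn(CCC2(N)OC(=O)C(OCc3ccccc3)=C2OCc2ccccc2)c(=O)n1` and compound 1 `Nc1ncn(CCC2(N)OC(=O)C(OCc3ccccc3)=C2OCc2ccccc2)c(=O)n1` have the same shared core and differ only in the six-membered aromatic ring hanging from the chain. In a functional assay on SW-620 cells (Homo sapiens) for inhibition, read by MTT assay, with a stated time of 72 h (on this read-out lower numbers stand for stronger inhibition and higher numbers for weaker inhibition), compound 2 gives > 100000 nM, which is a limit of the assay rather than a number. Compound 1 gives > 100000 nM in this assay, also a limit. The step that the two limits leave unreadable from compound 1 to compound 2 is therefore unreadable, since both values sit at the limit of > 100000 nM in this assay, at which 2 of the 2 values shown sit. Compound 3 `Cc1cn(CCC2(N)OC(=O)C(OCc3ccccc3)=C2OCc2ccccc2)c(=O)[nH]c1=O` carries the change (a group of 9 heavy atoms (5 carbon, 2 nitrogen, 2 oxygen; one six-membered aromatic ring with 2 hetero atoms) in place of a group of 8 heavy atoms (4 carbon, 3 nitrogen, 1 oxygen; one six-membered aromatic ring with 2 hetero atoms), on a saturated chain carbon, two bonds along the chain from a saturated ring carbon). Among the measured compounds shown here, no measured step bears on this change, so the expected step that the limit leaves unreadable from compound 2 to compound 3 rests on nothing firmer than the two limits. Compound 3 is estimated at 150000 nM, between 40000 nM and 600000 nM, most likely reported again only as a limit.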

Compound 3, half-maximal inhibitory concentration: > 100000 nM
Compound 3 was reported as a limit (the forecaster's own chance of this, stated with the estimate: 85%); the middle value lies beyond the limit too.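

The result for compound 3 in this assay is again only a limit, so the steps among compound 1, compound 2 and compound 3 cannot be read: the limit of > 100000 nM in this assay, at which 3 of the 3 values shown sit.

The compounds shown leave open whether changing the six-membered aromatic ring on the chain affects inhibition at all.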